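Serine protease 1 inhibition: a large group on the phenyl ring

A few compounds are considered here, and "the series" means these few. Any claim that something is new, unique, unknown or untested is made for them only; others in the source may bear on it.

Measured compounds:
compound 1, `CC1CCCC(C)N1CCCCCN1C(=O)C(c2ccccc2)Oc2ccccc21`, 2.8%
compound 2, `CC1CCCC(C)N1CCCCCN1C(=O)C(c2ccc(Cl)cc2)Oc2ccccc21`, 46%

In an assay on isolated protein for inhibition of serine protease 1 (Homo sapiens), tested at 100 uM (a higher number here means more inhibition at the concentration tested (going by the name of the read-out), a lower number less inhibition), compound 1 gives 2.8%, the lower of the two measured numbers. Compound 2 is `CC1CCCC(C)N1CCCCCN1C(=O)C(c2ccc(Cl)cc2)Oc2ccccc21`, and in this assay compound 2 gives 46%. Among the compounds with values here, the only measured step is a number 43.2 percentage points higher from compound 1 to compound 2 (beyond the scatter), so a single substituent on that aromatic ring has already moved the read-out a long way.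

Compound 3 is `CC1CCCC(C)N1CCCCCN1C(=O)C(c2cccc(C(=N)NN3CCOCC3)c2)Oc2ccccc21`. It differs from compound 1 in one place: a group of 9 heavy atoms (5 carbon, 3 nitrogen, 1 oxygen; one six-membered non-aromatic ring with 2 hetero atoms) in place of a hydrogen atom, on an aromatic carbon. Within the data shown here, no measured step covers a group of this size or kind, so the step from compound 1 to compound 2 is the only guide, and it bears on compound 3 only in that it shows a substituent on this ring can raise inhibition strongly. A rise is therefore expected, but with wide uncertainty. For compound 3 the expected step is a number 32.2 percentage points higher from compound 1 to compound 3 (beyond the scatter). Compound 3 is estimated at 35%, within a range from 5% to 75%.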

Compound 3, a percentage reported as inhibition, at one concentration (the size of the read-out at that concentration, not a potency): 58%
Beside the measured number, compound 3's estimate is 23 percentage points below it, and the stated range covers the measured number.
By their numbers in this assay, from the lowest: compound 1; then compound 2; then compound 3.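

On an aromatic carbon meta to a large group, a group of 9 heavy atoms in place of a hydrogen atom gives a number 55.2 percentage points higher from compound 1 to compound 3 (beyond the scatter) in this assay, so the ring can carry a substituent far larger than a single chloro and inhibition still climbs well clear of compound 1. Compound 2 and compound 3 differ in more than one place, so their numbers cannot say whether the new group or the chloro is the better change. Nothing measured here explains the rise, or shows which part of the new group is responsible.

On these data alone, it remains open whether a simple amine or a carboxylic acid on the same aromatic carbon would raise inhibition as well. The effect of the six-membered non-aromatic ring alone, without the rest of the group, is also unknown.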